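The compounds below may be only part of what the source reports. "The series", "measured", "known", "first", "only" and "open" are said of these compounds alone.

Compound 1 `Cn1c(-c2ccc([N+](=O)[O-])cc2)nc2cc(C(F)(F)F)ccc21` and compound 2 `Cn1c(-c2ccc(N)cc2)nc2cc(C(F)(F)F)ccc21` share one core and differ only in that (amino in place of nitro on an aromatic carbon). In an ADME assay on Vero cells (Chlorocebus sabaeus) for cytotoxicity (a higher number here means that more compound is tolerated, a lower number that less compound is tolerated), compound 1 gives only a limit, > 100000 nM. Compound 2 likewise gives only a limit in this assay, > 100000 nM. The step that the two limits leave unreadable from compound 1 to compound 2 thus cannot be read because of the limit of > 100000 nM in this assay, at which 2 of the 3 values shown sit. Compound 3 `COc1ccc(-c2nc3cc(Cl)c(Cl)cc3[nH]2)c([N+](=O)[O-])c1` carries a different core; how the two cores differ is not broken down here. In this assay compound 3 gives 80000 nM. Compound 4 `COc1ccc(-c2nc3cc(Cl)c(Cl)cc3[nH]2)c(N)c1` is compound 3 with amino in place of nitro on an aromatic carbon. This is the same kind of change as before, though not the same: in compound 1 the group sits para to a large group, in compound 3 ortho to a large group and meta to a methoxy group. Beside a step that the two limits leave unreadable from compound 1 to compound 2, the expected step is small, a 1.3-fold higher number from compound 3 to compound 4 (0.10 log units; within the scatter). That expectation rests on compound 3 giving 80000 nM and on the earlier step being unreadable. In this assay compound 4 is expected to give about 100000 nM, between 30000 nM and 300000 nM.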

Compound 4, half-maximal cytotoxic concentration: 75000 nM
Compound 4: the middle estimate sits 1.3-fold (0.12 log units) above what was measured; the measured number falls inside the stated range.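

On the core of compound 3, amino in place of nitro gives a 1.1-fold lower number from compound 3 to compound 4 (0.03 log units; within the scatter) in this assay, so here the swap leaves no readable difference in how much compound the cells tolerate. On the core of compound 1, the same swap cannot be read because of a limit of the assay: the limit of > 100000 nM in this assay, at which 2 of the 4 values shown sit. Among these compounds, the change has therefore been read on only one core, which shows nothing about whether it would behave alike on the other, where the group also sits in a different place.

The compounds shown leave open how a carboxylic acid or a nitrile in the same place would read in this assay. Also open, as far as these compounds go, is how the swap would read with an ethoxy group in place of the methoxy group.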